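This account rests on a few compounds, and the source may have more. Where it says the series, first, only, none or still open, it means among the compounds named here.

Three compounds have been measured in a functional assay on NCI-H460 cells (Homo sapiens) for cytotoxicity, read by MTT assay, with a stated time of 72 h; a lower number here means a stronger inhibitor, a higher number a weaker inhibitor:

compound 1, `CN(C)CCNc1nc(-c2ccc(NC(=O)Nc3ccc(F)cc3)cc2)nc2ccsc12`, gives 390 nM;
compound 2, `CN(C)CCNc1nc(-c2ccc(NC(=O)Nc3ccc(Cl)cc3)cc2)nc2ccsc12`, gives 130 nM;
compound 3, `CCN(CC)CCCNc1nc(-c2ccc(NC(=O)Nc3ccc(F)cc3)cc2)nc2c(Cl)c(Cl)sc12`, gives 450 nM.

Compound 1 and compound 2 share one core and differ in a single place: chloro in place of fluoro on an aromatic carbon. That change lowered the number, a 3.0-fold lower number from compound 1 to compound 2 (0.48 log units; beyond the scatter). Compound 3 carries a different core; the difference between the two cores is not broken down here. Compound 3 and compound 1 lie within the scatter of each other, so nothing can be said about their order. Compound 2 gives a lower number than compound 3, and that gap lies beyond the scatter.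

Compound 4, `CCN(CC)CCCNc1nc(-c2ccc(NC(=O)Nc3ccc(Cl)cc3)cc2)nc2c(Cl)c(Cl)sc12`, has not yet been measured. It arises from compound 3 by the same change, (chloro in place of fluoro on an aromatic carbon), at the same place. Going by the values given here, the only guide to its behaviour is the measured pair, and that step was seen on the other core; whether the second core answers in the same way is not known from these data. A step of comparable size is expected from compound 3 to compound 4, a 2.6-fold lower number from compound 3 to compound 4 (0.42 log units; beyond the scatter), because the same change gave a 3.0-fold lower number from compound 1 to compound 2 (0.48 log units; beyond the scatter) and compound 3 sits close to compound 1 in this assay. The range is kept wide to allow for the change carrying over less fully on the second core. Compound 4 is therefore estimated at 170 nM, with the likely span running from 80 nM to 400 nM.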

Compound 4, half-maximal inhibitory concentration: 270 nM
For compound 4 the middle estimate is 1.6-fold (0.20 log units) below the measured one; measured number inside the range.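

In this assay, chloro in place of fluoro on the second core gives a 1.7-fold lower number from compound 3 to compound 4 (0.22 log units; within the scatter), a step that on its own cannot be told apart from the ordinary spread of repeated measurements. Set beside the step on the first core, it does not differ from it by more than the scatter expected of two such steps: the same change on two cores in this assay, a 3.0-fold lower number (0.48 log units; beyond the scatter) from compound 1 to compound 2 and a 1.7-fold lower number (0.22 log units; within the scatter) from compound 3 to compound 4, 1.8-fold (0.26 log units) apart, within the scatter of two such steps. The result therefore fits the change carrying over in full, but it fits a much weaker effect on the second core equally well, and with a single pair on each core it neither proves that the two cores respond alike nor shows that they respond differently.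

The compounds shown compare only 4-fluorophenyl with 4-chlorophenyl, so it remains open whether bromo, methyl or methoxy in that same place would move the number further, and whether a larger step would stand clear of the scatter on both cores. The two cores also differ in both the amine chain and the chloro groups on the core of compound 3, and a compound carrying only one of these differences would be needed to tell their contributions apart.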